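The compounds below may be only part of what the source reports. "The series", "measured", "known", "first", "only" and "open" are said of these compounds alone.

The measured compounds are compound 1 `CC(=O)Nc1c(C(O)(C(F)(F)F)C(F)(F)F)ccc2ccccc12` and compound 2 `O=C(Nc1c(C(O)(C(F)(F)F)C(F)(F)F)ccc2ccccc12)c1cnco1`. In an assay on LtK cells with ATP-sensitive inward rectifier potassium channel 11 (Homo sapiens) as the target (on this read-out higher numbers stand for an effect only at larger amounts of compound and lower numbers for an effect already at smaller amounts), compound 1 gives 18 nM, and compound 2 gives 24 nM. The step of a 1.3-fold higher number from compound 1 to compound 2 (0.12 log units; within the scatter) lies within the scatter, so compound 2 does not stand apart from compound 1 on this assay.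

Compound 3 `O=C(Nc1c(C(O)(C(F)(F)F)C(F)(F)F)ccc2ccccc12)c1cccs1` has not yet been measured. It differs from compound 2 by thiophen-2-yl in place of 1,3-oxazol-5-yl on a carbonyl carbon. Within the data shown here, the only measured step that bears on this is the one from compound 1 to compound 2, where the group on the same carbonyl carbon was also exchanged; that step, a 1.3-fold higher number from compound 1 to compound 2 (0.12 log units; within the scatter), was within the scatter. On that single comparison, a change at this position is expected to move this assay little, and the step of no change at the digits printed from compound 2 to compound 3 (within the scatter) is expected to stay within the scatter. Compound 3 is therefore estimated at 24 nM, with a range from 10 nM to 60 nM.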

Compound 3, half-maximal effective concentration: 12 nM
For compound 3 the middle estimate is 2.0-fold (0.30 log units) above the measured one; low and high end bracket the measured number.
By their numbers in this assay, from the lowest: compounds 3, 1 and 2 (each within the scatter of the next).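

In this assay the exchange on the carbonyl carbon gives a 2.0-fold lower number from compound 2 to compound 3 (0.30 log units; within the scatter) and also a 1.5-fold lower number from compound 1 to compound 3 (0.18 log units; within the scatter). Methyl, 1,3-oxazol-5-yl and thiophen-2-yl thus all lie within the scatter of one another at this place, whereas the earlier pair covered only two groups, and a five-membered aromatic ring with one hetero atom, sulfur, fits this picture as well as the one with 2 hetero atoms. The data shown offer no measured explanation for these numbers.

The compounds leave open whether a group of another kind on this carbonyl carbon, such as an amine, a carboxylic acid or a longer chain, would also stay within the scatter. They also leave open whether these exchanges would read the same on a changed core.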